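Chain extension on the acetylated core of compound 3

The compounds below may be only part of what the source reports. "The series", "measured", "known", "first", "only" and "open" are said of these compounds alone.

Measured in a functional assay on CCRF-CEM cells (Homo sapiens), read by flow cytometry, with stated times of 16 h and 120 min, tested at 2.5 uM; a higher number here means a stronger effect of the compound at the concentration tested, a lower number a weaker effect:
compound 1, `CCCCCc1nc2c(c(C)c1O)CCN2C`: 63%
compound 2, `CCCCCCCCCCc1nc2c(c(C)c1O)CCN2C`: 84%
compound 3, `CCCCCc1nc2c(c(C)c1OC(C)=O)CCN2C`: 60%

Compound 3 holds the lowest of the three numbers; its nearest neighbour is compound 1, which sits within the scatter of it, and its furthest is compound 2, which lies beyond the scatter. The acetyl exchange itself moved little, as a number 3 percentage points lower from compound 1 to compound 3 (within the scatter) shows.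

Compound 4, `CCCCCCCCCCc1nc2c(c(C)c1OC(C)=O)CCN2C`, differs from compound 3 by pentyl in place of hydrogen on a saturated chain carbon, five bonds along the chain from an aromatic carbon. Going by the values given here, the one measured step that bears on this is the same change on the free hydroxyl core, a number 21 percentage points higher from compound 1 to compound 2 (beyond the scatter), a modest rise beyond the scatter. A rise of similar size is therefore expected for compound 4, as a number 20 percentage points higher from compound 3 to compound 4 (beyond the scatter). Compound 4 is estimated at 80%, within 66% to 94%.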

Compound 4, a percentage reported as activity, at one concentration (the size of the read-out at that concentration, not a potency): 82%
Beside the measured number, compound 4's estimate is 2 percentage points below it; the measured number falls inside the stated range.
By their numbers in this assay, from the lowest: compounds 3 and 1 (each within the scatter of the next); then compounds 4 and 2 (each within the scatter of the next).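

The pentyl change at this chain carbon now appears on a second core, with a number 22 percentage points higher from compound 3 to compound 4 (beyond the scatter), so the rise no longer rests on the free hydroxyl core alone: the same change on two cores in this assay, a number 21 percentage points higher (beyond the scatter) from compound 1 to compound 2 and a number 22 percentage points higher (beyond the scatter) from compound 3 to compound 4, 1 percentage points apart, within the scatter of two such steps

Acetyl in place of hydrogen on the oxygen on the aromatic ring also leaves the longer-chain pair level, with a number 2 percentage points lower from compound 2 to compound 4 (within the scatter): the same change on two cores in this assay, a number 3 percentage points lower (within the scatter) from compound 1 to compound 3 and a number 2 percentage points lower (within the scatter) from compound 2 to compound 4, 1 percentage points apart, within the scatter of two such steps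

From the compounds shown here alone, whether the rise continues with a still longer chain, or survives a chain ending in an amine, stays open. Going by these compounds, whether a benzoyl group on that oxygen would match acetyl also stays open.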